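The source may hold more compounds than are shown below. What is called first, only, known or untested is meant among the compounds shown, and "the series" means these compounds.

Working notes on a small diacylhydrazine series tested in an assay on cells for agonist activity at ecdysone receptor (Bombyx mori), read by a luciferase reporter, with a stated time of 24 h; on this read-out lower numbers stand for an effect already at smaller amounts and higher numbers for an effect only at larger amounts of compound. Of the compounds shown here, two have numbers so far. Compound 1 `Cc1cc(C)cc(C(=O)N(NC(=O)c2ccccc2)C(C)(C)C)c1` gives 69.2 nM in this assay. Compound 2 `Cc1ccccc1C(=O)NN(C(=O)c1ccccc1Cl)C(C)(C)C` gives 72.4 nM in this assay, and its number sits alongside that of compound 1, the gap between the two being within the scatter of repeat measurements, so the two read as indistinguishable on this read-out rather than as one being more or less active.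

The next compound, compound 3 `CC(C)(C)N(NC(=O)c1cccc(C#N)c1)C(=O)c1ccccc1Cl`, is obtained from compound 2 by a single change: 3-cyanophenyl in place of 2-methylphenyl on a carbonyl carbon. Among the compounds with values here, no pair of measured compounds differs in only one place, so nothing yet shows how a change of this kind moves the read-out; the expectation below rests on the structural change alone and on the fact that both measured compounds give similar numbers.

For compound 3 the step of a 1.7-fold higher number from compound 2 to compound 3 (0.22 log units; within the scatter) is expected to be modest, toward a somewhat higher number, though a result within the scatter of compound 2 would not surprise. The estimate for compound 3 in this assay is 120 nM, with a range from 40 nM to 400 nM.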

Compound 3, half-maximal effective concentration: 955 nM
For compound 3 the middle estimate is 8.0-fold (0.90 log units) below the measured one; the measured number lies above the stated range.
By their numbers in this assay, from the lowest: compounds 1 and 2 (each within the scatter of the next); then compound 3.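

In this assay, within the data shown here, this is the first comparison of two compounds that differ in one place, and it shows that the group on this carbonyl carbon can move the read-out strongly: 3-cyanophenyl in place of 2-methylphenyl gives a 13-fold higher number from compound 2 to compound 3 (1.12 log units; beyond the scatter) on the shared core. Compounds 1 and 2 differ in more than one place and give numbers within the scatter of each other, so they gave no sign of this sensitivity. Nothing available so far bears on the cause of this step.

The change from 2-methylphenyl to 3-cyanophenyl alters both the kind of group on the ring and its numbered place, so the compounds shown leave open which of the two carries the step, a question that 3-methylphenyl or 2-cyanophenyl on this carbonyl carbon would address. Also open, on these data alone, is how 3-methoxyphenyl or 3-carboxyphenyl and other groups behave at this place, and whether the same exchange would give a similar step on the core of compound 1.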